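Dropping One Methoxy from Compound 2: What to Expect

A few compounds are considered here, and "the series" means these few. Any claim that something is new, unique, unknown or untested is made for them only; others in the source may bear on it.

Of the compounds shown here, three have been tested so far in a functional assay on MDA-MB-231 cells (Homo sapiens) for cytotoxicity, read by MTT assay; a higher number here means a weaker inhibitor, a lower number a stronger inhibitor. Compound 1 `COc1ccc(-c2cn(-c3ccc(OC)cc3OC)nn2)cc1` gives only a limit there, > 10000 nM. Compound 2 `COc1cc(OC)cc(-c2cn(-c3cc(OC)c(OC)c(OC)c3)nn2)c1` likewise gives only a limit, > 10000 nM. Compound 3 `COc1ccc(-c2cn(-c3ccc(Oc4ccccc4)cc3)nn2)cc1OC` gives a measured value of 10000 nM. Compound 2 therefore stands at the edge of what this assay can read, sharing that position with compound 1, while compound 3 sits at a number of the same size; nothing separates the three beyond the usual scatter, and the picture is one of uniformly weak inhibitors, since (the limit of > 10000 nM in this assay, at which 2 of the 3 values shown sit).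

Compound 4 `COc1cc(OC)cc(-c2cn(-c3ccc(OC)c(OC)c3)nn2)c1` has not yet been tested. It differs from compound 2 by hydrogen in place of methoxy on an aromatic carbon. Within the data shown here, no pair of measured compounds differs in only one place, so there is no measured step to guide the expectation directly. With compound 2 sitting where it does, the step from compound 2 to compound 4 is expected to be small, a number no higher from compound 2 to compound 4 (the limit leaves the size open), with no change beyond the scatter in either direction. Compound 4 is therefore estimated at 10000 nM in this assay, somewhere between 3000 nM and 30000 nM, and quite possibly again only a limit.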

Compound 4, half-maximal inhibitory concentration: 10000 nM
For compound 4 middle estimate and measured number coincide at the digits printed; the range from low to high includes it.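

In this assay compound 2 gives > 10000 nM, which is a limit of the assay and not a number. Hydrogen in place of methoxy, on the aromatic carbon ortho to a methoxy group and meta to a large group, gives a number no higher from compound 2 to compound 4 (the limit leaves the size open), and this first comparison of two compounds differing in one place shows that this methoxy can leave without compound 4 moving clear of the weak end of the scale, at 10000 nM. How much the methoxy contributes at this position cannot be read, since the comparison rests on the edge of what the assay can report: the limit of > 10000 nM in this assay, at which 2 of the 4 values shown sit.

The compounds shown leave open whether another group on this same carbon, such as an amine, a hydroxyl or a carboxylic acid, would give a clearly lower number than compound 4 does. They also leave open whether a change elsewhere on the shared core, such as a longer chain in place of a methoxy, would bring any compound of this kind into the range where this assay can separate one from another.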